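The source may report more compounds than this note shows. Statements on the series, on what has been measured and on what is new or still open speak of the compounds shown alone.

Among the compounds with values here, compound 2 `CCOC(=O)C1=Cc2ccccc2OC1(OCc1cn(CC(=O)Nc2cccc(Cl)c2)nn1)C(F)(F)F` gives, in a functional assay on MCF7 cells (Homo sapiens) for inhibition, read by MTT assay, with a stated time of 24 h (on this read-out higher numbers stand for weaker inhibition and lower numbers for stronger inhibition), 11600 nM, numerically the higher of the two numbers so far; its only neighbour is compound 1 `CCOC(=O)C1=Cc2ccccc2OC1(OCc1cn(-c2ccc(F)cc2)nn1)C(F)(F)F`, which in this assay gives 9100 nM, so the gap of a 1.3-fold higher number from compound 1 to compound 2 (0.11 log units; within the scatter) is within the scatter. The change to compound 3 `CCOC(=O)C1=Cc2ccccc2OC1(OCc1cn(-c2cccc(OC)c2)nn1)C(F)(F)F` is 3-methoxyphenyl in place of ((3-chlorophenyl)carbamoyl)methyl on an aromatic nitrogen; it puts an aryl group directly on the ring nitrogen again, as in compound 1. Within the data shown here, the single measured step bearing on this position, a 1.3-fold higher number from compound 1 to compound 2 (0.11 log units; within the scatter), exchanged one such aryl group for the carbamoylmethyl group without moving the number beyond the scatter. Nothing measured here separates one aryl substituent on that nitrogen from another. For compound 3 a step of a 1.3-fold lower number from compound 2 to compound 3 (0.11 log units; within the scatter) is expected in this assay, nothing beyond the scatter. Compound 3 is therefore estimated at 9000 nM, with a range of 3500 nM to 23000 nM.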

Compound 3, half-maximal inhibitory concentration: > 150000 nM
Compound 3: only a limit was reported; the forecaster's own chance of this, stated with the estimate: 10%; middle value at least 16-fold (1.22 log units) away from the limit.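

Compound 3 gives a limit, not a number: the limit of > 150000 nM in this assay, at which 1 of the 3 values shown sits.

Read against that limit, 3-methoxyphenyl in place of 4-fluorophenyl gives an at least 16-fold higher number from compound 1 to compound 3 (1.21 log units; beyond the scatter), so exchanging one aryl group on the aromatic nitrogen for another can produce a large step, which the earlier compounds did not show. 3-Methoxyphenyl in place of ((3-chlorophenyl)carbamoyl)methyl likewise gives an at least 12-fold higher number from compound 2 to compound 3 (1.11 log units; beyond the scatter), although a 1.3-fold higher number from compound 1 to compound 2 (0.11 log units; within the scatter) had left this position looking insensitive to the change of group.

The compounds shown do not separate the presence of the methoxy group from the absence of fluorine, and the limit leaves the full size of both steps unknown. Going by these compounds, how an amine or a carboxylic acid on the phenyl ring, or a longer chain on the aromatic nitrogen, would read in this assay remains open.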